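Arylamino in place of azetidinyl on a tricyclic quinone core

The compounds below may be only part of what the source reports. "The series", "measured", "known", "first", "only" and "open" are said of these compounds alone.

Compound 1, `O=C1C=C(N2CCC2)C(=O)c2c1nc1n2[C@H]2OC[C@@H](O)[C@H]2OC1`: in a functional assay on ECa-109 cells for inhibition, with ECa-109 cell line (Homo sapiens) as the target, read by sulforhodamine B assay (a lower number here means a stronger inhibitor, a higher number a weaker inhibitor), compound 1 reports only a limit, > 16000 nM.
Compound 2, `CCCc1ccc(NC2=CC(=O)c3c(nc4n3[C@H]3OC[C@@H](O)[C@H]3OC4)C2=O)cc1`: in this assay compound 2 reports only a limit, > 4000 nM.
Compound 3, `O=C1C(NC2CCCCC2)=CC(=O)c2c1nc1n2[C@H]2OC[C@@H](O)[C@H]2OC1`: in this assay compound 3 reports only a limit, > 16000 nM.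

No measured number exists in this set. Compound 1 sits at the limit of > 16000 nM in this assay, at which 2 of the 3 values shown sit, shared with compound 3. Compound 2 sits at the limit of > 4000 nM in this assay, at which 1 of the 3 values shown sits. Among the compounds with values here, the one step that can be traced, a step that the two limits leave unreadable from compound 2 to compound 3, stays unreadable because both ends are limits, so it says nothing about direction or size.

Compound 4, `O=C1C=C(Nc2cccc(Cl)c2)C(=O)c2c1nc1n2[C@H]2OC[C@@H](O)[C@H]2OC1`, differs from compound 1 by (3-chlorophenyl)amino in place of azetidin-1-yl on a double-bonded ring carbon. Compound 2 carries an arylamino group at the same kind of position and gives no number either, and compound 3 with its cyclohexylamino group matches compound 1. Nothing among the three measured compounds points to a change beyond the scatter in either direction, and the most likely outcome is another limit.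

Compound 4 is therefore expected to reach about 20000 nM in this assay, with a range from 4000 nM to 80000 nM, which would mean a step that the limit leaves unreadable from compound 1 to compound 4 from compound 1.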

Compound 4, half-maximal inhibitory concentration: 4690 nM
Compound 4: the middle estimate sits 4.3-fold (0.63 log units) above what was measured; measured number inside the range.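

Within the data shown here, the exchange of azetidin-1-yl for (3-chlorophenyl)amino on a double-bonded ring carbon gives an at least 3.4-fold lower number from compound 1 to compound 4 (0.53 log units; beyond the scatter) in this assay, the first step in this set with a readable direction. Among these compounds, with compound 4 the series gains its first measured number, which shows that the group at this place on the shared core can move the read-out, something the earlier compounds could not show while all their values were limits and the step between compound 2 and compound 3 could not be read. The step gives only a minimum size, since its starting point is a limit and not a number: the limit of > 16000 nM in this assay, at which 2 of the 4 values shown sit.

The compounds shown do not separate the part played by the chlorine from that of the phenyl ring or the amine hydrogen, and a plain phenylamino group at the same place would be needed to isolate the chlorine. Nor do they say how a larger ring without that hydrogen, such as piperidin-1-yl, would compare with azetidin-1-yl or with (3-chlorophenyl)amino in this assay.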